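Removing a Pyridine Methyl: Expected Effect on Rat Clearance

The compounds below may be only part of what the source reports. "The series", "measured", "known", "first", "only" and "open" are said of these compounds alone.

Compound 1, `CC[C@H](C)[C@@H]1C(=O)N[C@H](C2Cc3ccccc3C2)C(=O)N1[C@@H](C(=O)N(C)C)c1ccc(C)[n+]([O-])c1`: 28 mL/min/kg
Compound 2, `CC[C@H](C)[C@@H]1C(=O)N[C@H](C2Cc3ccccc3C2)C(=O)N1[C@@H](C(=O)N(C)C)c1ccc(C)nc1C`: 15 mL/min/kg
Compound 3, `CCC(CC)[C@@H]1C(=O)N[C@H](C2Cc3ccccc3C2)C(=O)N1[C@@H](C(=O)N1CCOCC1)c1ccc(C)nc1C`: 15 mL/min/kg

All three were studied in an in vivo ADME assay on the whole organism for pharmacokinetics, with Rattus norvegicus as the target, at a dose of 5 mg/kg; a lower number here means slower removal, a higher number faster removal of the compound. Compound 3 stands level with compound 2 at the digits shown, and the two together give the lowest numbers of the three. Against compound 1, compound 3 shows a lower number, but the gap is within the scatter. Within the data shown here, the only single-site step among the measured compounds is a 1.9-fold lower number from compound 1 to compound 2 (0.27 log units; within the scatter), and that step, too, stays within the scatter.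

Compound 4, `CCC(CC)[C@@H]1C(=O)N[C@H](C2Cc3ccccc3C2)C(=O)N1[C@@H](C(=O)N1CCOCC1)c1ccc(C)nc1`, differs from compound 3 in one place: hydrogen in place of methyl on an aromatic carbon. Cut one bond further out, the 2,6-dimethylpyridin-3-yl group becomes a 6-methylpyridin-3-yl group. Among the measured compounds shown here, no measured step removes a methyl from this ring, so there is no direct precedent. For the measured compounds named here, the one change made on the same ring, from compound 1 to compound 2, did not move this assay beyond the scatter, and the change here is smaller. The expected step is therefore a 1.1-fold higher number from compound 3 to compound 4 (0.05 log units; within the scatter), that is, nothing beyond the scatter.

Compound 4 is thus estimated to give 17 mL/min/kg in this assay, with a range from 9 mL/min/kg to 34 mL/min/kg.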

Compound 4, clearance: 23 mL/min/kg
Compound 4: the middle estimate sits 1.4-fold (0.13 log units) below what was measured, and the stated range covers the measured number.
By their numbers in this assay, from the lowest: compounds 2, 3, 4 and 1 (each within the scatter of the next).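

In this assay, replacing the methyl with hydrogen on the aromatic carbon next to the ring nitrogen gives a 1.5-fold higher number from compound 3 to compound 4 (0.19 log units; within the scatter), the only direct reading at this position among the compounds shown. Among these compounds, earlier comparisons could only suggest what this methyl might contribute, whereas this matched pair isolates that one change while the rest of the molecule stays the same. In this pair, the 2,6-dimethylpyridin-3-yl and 6-methylpyridin-3-yl groups cannot be told apart in rat clearance, and no measurement shown here offers an explanation for the size of this step.

A single pair cannot show whether the same swap would stay within the scatter on a different background, such as the dimethylamide and side chain of compound 2, or whether the other methyl on this ring can be removed in the same way. As far as these compounds go, it also remains open how rat clearance would respond to a larger or different group at this position, such as an ethyl group, a methoxy group, a chlorine atom or an amine.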